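Removing the para-chloro from a benzoylacrylic acid

The source may hold more compounds than are shown below. What is called first, only, known or untested is meant among the compounds shown, and "the series" means these compounds.

Measured so far:
compound 1 `CC(C)(C)c1ccc(C(=O)/C=C/C(=O)O)cc1` — 8740 nM
compound 2 `O=C(O)/C=C/C(=O)c1ccc(Cl)cc1` — 28700 nM

In a functional assay on LS174T cells (Homo sapiens) for inhibition, read by MTT assay, with a stated time of 72 h (on this read-out lower numbers stand for stronger inhibition and higher numbers for weaker inhibition), compound 1 gives 8740 nM, and compound 2 gives 28700 nM. Among the measured compounds shown here, compound 2 therefore stands at the highest number of the two, with compound 1 as its only neighbour at a lower number. For the measured compounds named here, the single measured step, a 3.3-fold higher number from compound 1 to compound 2 (0.52 log units; beyond the scatter), shows a modest rise when chloro replaces tert-butyl.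

Compound 3 `O=C(O)/C=C/C(=O)c1ccccc1` carries a change of one atom: hydrogen in place of chloro on an aromatic carbon. Going by the values given here, no measured step concerns hydrogen at that position, so only the size of the chloro step offers a scale. Leaving the chloro out is expected to move this assay by a small amount, and in which direction is uncertain; the estimated step is a 1.2-fold higher number from compound 2 to compound 3 (0.09 log units; within the scatter). For compound 3 the estimate is 35000 nM with a range from 12000 nM to 100000 nM.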

Compound 3, half-maximal inhibitory concentration: 45500 nM
Estimate against measurement, compound 3: 1.3-fold (0.11 log units) below, within the range that was stated.
By their numbers in this assay, from the lowest: compound 1; then compounds 2 and 3 (each within the scatter of the next).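

In this assay hydrogen in place of chloro gives a 1.6-fold higher number from compound 2 to compound 3 (0.20 log units; within the scatter) and so leaves the two groups at this position indistinguishable. Hydrogen in place of tert-butyl gives a 5.2-fold higher number from compound 1 to compound 3 (0.72 log units; beyond the scatter) and confirms that compound 1 alone stands apart from the other two. No measured evidence here accounts for this difference. Going by these compounds, what remains open is whether the lower number belongs to tert-butyl alone or would also appear with a methyl or an isopropyl group. On these data alone, the effect of an amine or a methoxy group at this position is also open.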